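Trimming the acid-bearing ester down to a phenol

The compounds below may be only part of what the source reports. "The series", "measured", "known", "first", "only" and "open" are said of these compounds alone.

Two compounds share one core. Compound 1 `Cc1c(C)c2c(c(C)c1OC(=O)CCC(=O)NC1CC(C)(C)N([O])C1(C)C)CCC(C)(C(=O)NC1CC(C)(C)N([O])C1(C)C)O2` is the larger of the pair, and compound 2 `Cc1c(C)c2c(c(C)c1OC(=O)CCC(=O)O)CCC(C)(C(=O)NC1CC(C)(C)N([O])C1(C)C)O2` is the smaller. In a functional assay on HepG2 cells (Homo sapiens) for cytotoxicity, read by MTT assay, with a stated time of 72 h (on this read-out lower numbers stand for stronger inhibition and higher numbers for weaker inhibition), compound 1 reaches only a limit of the assay, > 300000 nM. Compound 2 likewise gives only a limit in this assay, > 300000 nM. Because (the limit of > 300000 nM in this assay, at which 2 of the 2 values shown sit), the step that the two limits leave unreadable from compound 1 to compound 2 cannot be read as a number. Compound 3 `Cc1c(C)c2c(c(C)c1O)CCC(C)(C(=O)NC1CC(C)(C)N([O])C1(C)C)O2` is the next change: hydrogen in place of (2-carboxyethyl)carbonyl on an oxygen on an aromatic ring. Among the compounds with values here, no measured step bears on this change other than that unreadable one, and compound 2 stands at the limit rather than at a number. Within the data shown here, the expectation is therefore that compound 3 gives no step that can be read, so a number no higher from compound 2 to compound 3 (the limit leaves the size open) is expected to stay unreadable. Compound 3 is estimated at 300000 nM with a range from 100000 nM to 1000000 nM, most likely again only a limit.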

Compound 3, half-maximal inhibitory concentration: 145000 nM
The estimate for compound 3 lay 2.1-fold (0.32 log units) above the measured number; measured number inside the range.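

In this assay, within the data shown here, replacing the (2-carboxyethyl)carbonyl on this oxygen with hydrogen gives an at least 2.0-fold lower number from compound 2 to compound 3 (0.31 log units; beyond the scatter) and is the first step that can be read. Its size is only a minimum, so the true gap may be wider. The earlier step cannot be read, and compound 3 is the only one of the three with a measured number, showing that this change on the oxygen can move the read-out off the assay limit shared by the other two: the limit of > 300000 nM in this assay, at which 2 of the 3 values shown sit.

The compounds shown leave open how a small group on this oxygen, such as a methyl or an acetyl, would compare with hydrogen. They also do not separate the effect of having a free hydroxy from that of losing the chain.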